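The source may hold more compounds than are shown below. What is called first, only, known or untested is meant among the compounds shown, and "the series" means these compounds.

This account follows a single change made to compound 1 `C#Cc1nc(C(=O)OCC)cs1`, which carries an ethynyl group on its five-membered aromatic core. In a functional assay on HCT-116 cells (Homo sapiens) for cytotoxicity, with a stated time of 3 days (a higher number here means a weaker inhibitor, a lower number a stronger inhibitor), compound 1 gives > 40000 nM, which is a limit of the assay rather than a measured number. Compound 2 `Ic1nc2ccccc2s1`, built on a different core, has also been tested. In this assay compound 2 gives > 40000 nM, again a limit of the assay and not a number. Where compound 1 stands is therefore told only by the limit of > 40000 nM in this assay, at which 2 of the 2 values shown sit; no measured number separates it from compound 2, and no step between measured compounds can be computed. Compound 3 `C=Cc1nc(C(=O)OCC)cs1` differs from compound 1 in one place, (vinyl in place of ethynyl on an aromatic carbon). Since both measured values rest on (the limit of > 40000 nM in this assay, at which 2 of the 2 values shown sit), the step from compound 1 to compound 3 is expected to be a step that the limit leaves unreadable from compound 1 to compound 3, that is, none beyond the usual scatter. Compound 3 is accordingly expected to give about 45000 nM in this assay, within a range of 15000 nM to 150000 nM, and most probably to be reported once more only as a limit.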

Compound 3, half-maximal inhibitory concentration: > 40000 nM
Compound 3: a limit, no number; the forecaster's own chance of this, stated with the estimate: 80%; the middle value is on the limit's open side.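

No step can be read between compound 1 and compound 3 in this assay, because both are reported only as a limit and neither gives a number: the limit of > 40000 nM in this assay, at which 3 of the 3 values shown sit.

The compounds shown leave open whether ethynyl and vinyl differ at all in this assay, and which change to the core of compound 1 would yield a measured number.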